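The compounds below may be only part of what the source reports. "The series", "measured", "known", "first", "only" and "open" are said of these compounds alone.

In an ADME assay on a cell-free system (plasma, Rattus norvegicus) for metabolic stability, read by LC-MS, with a stated time of 1 h, tested at 100 uM (a higher number here means that more of the compound is left, a lower number that less of the compound is left), compound 1 `CC1=C(c2nc(-c3ccc(C#N)cc3)cs2)C(c2ccc(Br)nc2)NC(=O)N1` gives 98.3%, and compound 2 `COc1ccc(C2NC(=O)NC(C)=C2c2nc(-c3ccc(C#N)cc3)cs2)cn1` gives 100%. These two numbers lie within the usual scatter of each other, so compound 2 stands level with compound 1, and both sit close to the top of the scale. Compound 3 `CC1=C(c2nc(-c3ccc(C#N)cc3)cs2)C(c2cccc(O)c2)NC(=O)N1` keeps the shared core but carries 3-hydroxyphenyl in place of 6-methoxypyridin-3-yl on a saturated ring carbon. Going by the values given here, only one measured step bears on this swap. Methoxy in place of bromo, a change within the group that now leaves, gave a number 1.7 percentage points higher from compound 1 to compound 2 (within the scatter). That step is small, but it is thin evidence: neither measured compound has a hydroxy group or a ring of carbon only in this place. No step beyond the scatter is therefore expected in this assay, although a drop cannot be ruled out. Put as a step, the estimated change is a number 4 percentage points lower from compound 2 to compound 3 (within the scatter). The expected value for compound 3 is 96%, with an estimated range from 84% to 100%.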

Compound 3, percent of the compound remaining: 88.5%
The estimate for compound 3 lay 7.5 percentage points above the measured number; the range from low to high includes it.
By their numbers in this assay, from the lowest: compounds 3, 1 and 2 (each within the scatter of the next, the first and the last beyond it).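

In this assay, the saturated ring carbon of the shared core turns out to be a place where a change of aromatic group can move the number beyond the usual scatter: 3-hydroxyphenyl in place of 6-methoxypyridin-3-yl gives a number 11.5 percentage points lower from compound 2 to compound 3 (beyond the scatter). The same group in place of 6-bromopyridin-3-yl gives a number 9.8 percentage points lower from compound 1 to compound 3 (within the scatter), so the step beyond the scatter appears against only one of the two pyridine compounds, and the result is a modest signal rather than a firm rule about this position. Nothing among the data explains why this step occurs.

This swap removes the ring nitrogen and the methoxy group and brings in a hydroxy group, all in one move, so the compounds shown cannot tell which of these changes carries the step. A plain phenyl ring or a 3-methoxyphenyl group on the same carbon would pull these changes apart, and whether an aminophenyl or a carboxyphenyl group would behave like 3-hydroxyphenyl in this assay remains an open question.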